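Adding a Methoxy Group: From Compound 3 to Compound 4

The compounds below may be only part of what the source reports. "The series", "measured", "known", "first", "only" and "open" are said of these compounds alone.

Compound 3 `COc1cccc(NS(=O)(=O)c2ccc(N3CCNC3=O)cc2)c1` gives 240 nM in a functional assay on SK-OV-3 cells (Homo sapiens) for antiproliferative activity, read by sulforhodamine B assay, with a stated time of 48 h (a higher number here means a weaker inhibitor, a lower number a stronger inhibitor), the highest of the three numbers. Compound 1 `O=C1NCCN1c1ccc(S(=O)(=O)Nc2cccc(Br)c2)cc1` lies nearest with 170 nM; the step of a 1.4-fold higher number from compound 1 to compound 3 (0.15 log units; within the scatter) is within the scatter. Compound 2 `COc1cc(NS(=O)(=O)c2ccc(N3CCNC3=O)cc2)cc(OC)c1OC` lies furthest, with 22 nM, beyond the scatter.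

Compound 4 `COc1cc(NS(=O)(=O)c2ccc(N3CCNC3=O)cc2)cc(OC)c1` differs from compound 3 by methoxy in place of hydrogen on an aromatic carbon, on a carbon meta to a methoxy group. For the measured compounds named here, no measured single step covers this change; the only one, a 1.4-fold higher number from compound 1 to compound 3 (0.15 log units; within the scatter), concerns another exchange. Compound 2, however, carries methoxy groups that compound 3 lacks, and the values of compound 3 and compound 2 point toward lower numbers when methoxy groups are added. Compound 4 is therefore expected to move part of that way, a 3.4-fold lower number from compound 3 to compound 4 (0.54 log units; beyond the scatter). Compound 4 is estimated at 70 nM, between 25 nM and 200 nM.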

Compound 4, half-maximal inhibitory concentration: 170 nM
Beside the measured number, compound 4's estimate is 2.4-fold (0.39 log units) below it; the measured number falls inside the stated range.
By their numbers in this assay, from the lowest: compound 2; then compounds 1, 4 and 3 (each within the scatter of the next).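

In this assay, methoxy in place of hydrogen on this aromatic carbon, meta to a methoxy group, stays within the scatter (a 1.4-fold lower number from compound 3 to compound 4 (0.15 log units; within the scatter)). The step beyond the scatter lies instead with the methoxy group that compound 2 carries and compound 4 lacks (a 7.7-fold higher number from compound 2 to compound 4 (0.89 log units; beyond the scatter)). Nothing shown here gives a reason for this difference.

The compounds shown leave open whether an ethoxy group or an amine on the carbon of that added methoxy group would also stay within the scatter. They also leave open how a hydroxyl group would serve in place of the methoxy group that separates compound 2 from compound 4.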